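Trading a Methoxy for a Methyl in Compound 4

The source may hold more compounds than are shown below. What is called first, only, known or untested is meant among the compounds shown, and "the series" means these compounds.

Of the compounds shown here, three have been measured in an assay on COS-1 cells for inhibition of alkaline phosphatase, tissue-nonspecific isozyme (Homo sapiens), read by colorimetric assay; on this read-out higher numbers stand for weaker inhibition and lower numbers for stronger inhibition. Compound 1 `COc1cc(C)c(Cl)cc1S(=O)(=O)Nc1cccnc1` gives 510 nM. Compound 2 `COc1cc(S(=O)(=O)Nc2cccnc2)c(OC)cc1C` gives 1490 nM, and compound 3 `COc1cc(S(=O)(=O)Nc2cccnc2)c(OC)cc1Br` gives 1550 nM. Compound 2 thus stands second highest of the three numbers: its nearest neighbour is compound 3, whose number lies within the scatter of it, while compound 1 sits furthest away, and the step of a 2.9-fold higher number from compound 1 to compound 2 (0.47 log units; beyond the scatter) is beyond the scatter. The step of a 1.0-fold higher number from compound 2 to compound 3 (0.02 log units; within the scatter), by contrast, stays within the scatter.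

Compound 4 `COc1cc(C)c(C)cc1S(=O)(=O)Nc1cccnc1` has not yet been measured. It differs from compound 2 by methyl in place of methoxy on an aromatic carbon. Among the compounds with values here, no measured step makes exactly this exchange. The closest bearing comes from the step of a 2.9-fold higher number from compound 1 to compound 2 (0.47 log units; beyond the scatter), in which a methoxy entered for a chloro and the number rose modestly; removing a methoxy in favour of a methyl might undo part of that rise. The step of a 1.0-fold higher number from compound 2 to compound 3 (0.02 log units; within the scatter), which touched a different group, was flat. Compound 4 is therefore expected to show a modestly lower number in this assay, estimated at 750 nM with a range from 350 nM to 1600 nM, which amounts to an expected step of a 2.0-fold lower number from compound 2 to compound 4 (0.30 log units; within the scatter).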

Compound 4, half-maximal inhibitory concentration: 1680 nM
The estimate for compound 4 lay 2.2-fold (0.35 log units) below the measured number, outside the stated range (above it).
By their numbers in this assay, from the lowest: compound 1; then compounds 2, 3 and 4 (each within the scatter of the next).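

In this assay the step from methoxy to methyl at this position, ortho to a methyl group and para to a methoxy group, stays within the scatter (a 1.1-fold higher number from compound 2 to compound 4 (0.05 log units; within the scatter)), so the hydrogen-bond acceptor that leaves with the methoxy goes without a change that can be told from noise. The comparison that compound 4 adds is with chloro at the same place: the step to methyl (a 3.3-fold higher number from compound 1 to compound 4 (0.52 log units; beyond the scatter)) is beyond the scatter and close in size to the step to methoxy (a 2.9-fold higher number from compound 1 to compound 2 (0.47 log units; beyond the scatter)), so the higher number seen earlier was not particular to methoxy, and among the three groups tried here only the chloro of compound 1 stands apart. Nothing available accounts for why chloro differs from the other two groups.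

The compounds shown leave open whether a fluoro, an amine or a longer chain such as ethyl at this position would fall with chloro or with methyl and methoxy. They also leave open whether the gap between chloro and methyl would hold if the methoxy para to this position were replaced by another group, such as a hydroxyl.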